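The source may report more compounds than this note shows. Statements on the series, on what has been measured and on what is new or still open speak of the compounds shown alone.

Compound 1, `Cc1ccc(/C=C/C(=O)c2cccc(NC(=O)c3cc(-c4ccncc4)n[nH]3)c2)cc1`, gives 69400 nM in a functional assay, read by spectrophotometry, tested at 100 uM; on this read-out lower numbers stand for stronger inhibition and higher numbers for weaker inhibition.
Compound 2, `O=C(/C=C/c1ccc(F)cc1)c1cccc(NC(=O)c2cc(-c3ccncc3)n[nH]2)c1`, gives 56000 nM in this assay.
Compound 3, `COc1ccc(/C=C/C(=O)c2cccc(NC(=O)c3cc(-c4ccncc4)n[nH]3)c2)cc1`, gives 38400 nM in this assay.

The three measured compounds share one core and differ only in the group on the aromatic carbon para to the large group of the ethenyl arm: methyl, fluoro and methoxy. All three numbers sit close together. From compound 1 to compound 2 the change is a 1.2-fold lower number from compound 1 to compound 2 (0.09 log units; within the scatter), from compound 1 to compound 3 it is a 1.8-fold lower number from compound 1 to compound 3 (0.26 log units; within the scatter), and from compound 2 to compound 3 it is a 1.5-fold lower number from compound 2 to compound 3 (0.16 log units; within the scatter). Compound 3 therefore stands within the scatter of both compound 2 and compound 1, and nothing separates the three beyond the usual spread.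

Compound 4, `O=C(/C=C/c1ccc([N+](=O)[O-])cc1)c1cccc(NC(=O)c2cc(-c3ccncc3)n[nH]2)c1`, differs from compound 3 by nitro in place of methoxy on an aromatic carbon. For the measured compounds named here, the steps that bear on this are those that exchange the group at the same place, and all of them stayed within the scatter. Nothing measured here points to a step beyond the scatter in this assay in either direction. The step from compound 3 to compound 4 is expected to be a 1.0-fold higher number from compound 3 to compound 4 (0.02 log units; within the scatter). Compound 4 is accordingly estimated at 40000 nM, with a range from 15000 nM to 100000 nM.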

Compound 4, half-maximal inhibitory concentration: 52800 nM
Compound 4: middle estimate off by 1.3-fold (0.12 log units), on the low side, within the range that was stated.
By their numbers in this assay, from the lowest: compounds 3, 4, 2 and 1 (each within the scatter of the next).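

In this assay, nitro on the aromatic carbon para to a large group stays within the scatter of all three other groups at that place (a 1.4-fold higher number from compound 3 to compound 4 (0.14 log units; within the scatter); a 1.1-fold lower number from compound 2 to compound 4 (0.03 log units; within the scatter); a 1.3-fold lower number from compound 1 to compound 4 (0.12 log units; within the scatter)). The earlier compounds had shown this flat response only among methyl, fluoro and methoxy, and it now extends to nitro, which brings nitrogen and a double bond outside aromatic rings to this position, so the exchange of methoxy for nitro leaves the read-out where it was within the usual spread. No independent evidence speaks to why these four groups read alike.

The four compounds leave open whether an amine, a carboxylic acid or a plain hydrogen at this place would move the number beyond the scatter, or whether this position responds to no exchange at all. They also leave open whether a change elsewhere in the shared core, such as at the amide hydrogen or in the ethenyl arm, would separate compounds in a way that these exchanges do not.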